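Inverting the Chain Stereocentre of Compound 3

The source may report more compounds than this note shows. Statements on the series, on what has been measured and on what is new or still open speak of the compounds shown alone.

Measured compounds:
compound 1, `CC(C)c1cccc(C(C)C)c1NC(=O)CC(=O)Oc1c(C(C)C)cccc1C(C)C`: 42 nM
compound 2, `Cc1cccc(C)c1NC(=O)CC(=O)Oc1c(C(C)C)cccc1C(C)C`: 210 nM
compound 3, `CCCCCCCCCCCC[C@@H](C)OC(=O)CC(=O)Nc1c(C(C)C)cccc1C(C)C`: 4 nM

In an assay on microsomes from intestine for inhibition of acyl-CoA:cholesterol acyltransferase (Oryctolagus cuniculus) (on this read-out higher numbers stand for weaker inhibition and lower numbers for stronger inhibition), compound 3 gives the lowest number of the three measured compounds; compound 1 gives a higher number, and compound 2 gives the highest, both of these gaps lying beyond the scatter. Compound 4 `CCCCCCCCCCCC[C@H](C)OC(=O)CC(=O)Nc1c(C(C)C)cccc1C(C)C` is its mirror-image partner at one point: the two compounds have the same atoms and bonds and differ only in configuration as drawn: 1 of 1 stereo elements differ; a stereocentre at a saturated chain carbon is drawn R in compound 3 and S in compound 4. For the measured compounds named here, no measured pair shows what such an inversion does here, so the direction and size of the step are open. Mirror-image pairs often differ only modestly, though large gaps also occur. Compound 4 is expected to be a little weaker, with the step of a 2.5-fold higher number from compound 3 to compound 4 (0.40 log units; beyond the scatter) estimated as small and uncertain. For compound 4 the estimate is 10 nM, within a range from 3 nM to 60 nM.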

Compound 4, half-maximal inhibitory concentration: 4 nM
For compound 4 the middle estimate is 2.5-fold (0.40 log units) above the measured one; low and high end bracket the measured number.
By their numbers in this assay, from the lowest: compounds 3 and 4 (each within the scatter of the next); then compound 1; then compound 2.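

In this assay, inverting the stereocentre at the saturated chain carbon gives no change at the digits printed from compound 3 to compound 4 (within the scatter). For the compounds shown here, compounds 1 and 2 carry no such stereocentre, so only this pair shows that drawing this carbon R or S makes no readable difference here. The comparison tests that single point: the fact that compounds 3 and 4 differ only in the configuration as drawn

From the compounds shown here alone, whether configuration matters as little with an ethyl group in place of the methyl group on this carbon remains open. So does the effect of a carboxylic acid on the long chain.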